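Replacing Ethyl with Imidazol-1-yl on the Amine Chain

The source may report more compounds than this note shows. Statements on the series, on what has been measured and on what is new or still open speak of the compounds shown alone.

Measured so far in an ADME assay on Vero cells (Chlorocebus sabaeus) for cytotoxicity, with a stated time of 72 h; a higher number here means that more compound is tolerated, a lower number that less compound is tolerated:
compound 1 `O=C(/C=C/c1ccc(Cl)cc1)c1ccc(N2CCCCC2)cc1` gives 235 ug/mL
compound 2 `CCCCNc1ccc(C(=O)C2CC2c2ccc(Cl)cc2)cc1` gives 316 ug/mL
compound 3 `CCCCCCCCCCCCCCCCNc1ccc(C(=O)C2CC2c2ccc(Cl)cc2)cc1` gives 410 ug/mL

Compound 2 holds the second highest of these three numbers. Its nearest neighbour on the numbers is compound 3 and its furthest is compound 1, and both gaps lie within the usual scatter of this assay, so no order among the three compounds can be claimed. Compound 4 `O=C(c1ccc(NCCn2ccnc2)cc1)C1CC1c1ccc(Cl)cc1` has not yet been measured in this assay. It differs from compound 2 in one place: 1H-imidazol-1-yl in place of ethyl on a saturated chain carbon, two bonds along the chain from a nitrogen on an aromatic ring. Among the measured compounds shown here, no measured pair shows a comparable change, so the direction of the step is not fixed by the data. The expected step is a 1.1-fold lower number from compound 2 to compound 4 (0.02 log units; within the scatter), that is, none beyond the scatter. Compound 4 is estimated at 300 ug/mL, with a range from 150 ug/mL to 600 ug/mL.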

Compound 4, half-maximal cytotoxic concentration: 243 ug/mL
Estimate against measurement, compound 4: 1.2-fold (0.09 log units) above; measured number inside the range.
By their numbers in this assay, from the lowest: compounds 1, 4, 2 and 3 (each within the scatter of the next).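

In this assay, among the compounds shown here, 1H-imidazol-1-yl in place of ethyl on this saturated chain carbon gives a 1.3-fold lower number from compound 2 to compound 4 (0.11 log units; within the scatter) and so provides the first measured step at this position. A five-membered aromatic ring with 2 hetero atoms can thus stand here with no change beyond the scatter. No available evidence bears on this result. On these data alone, whether a carboxylic acid or a primary amine at the same place would also stay within the scatter remains open. So does whether a longer chain carrying 1H-imidazol-1-yl would do so.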